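This account rests on a few compounds, and the source may have more. Where it says the series, first, only, none or still open, it means among the compounds named here.

Measured compounds:
- compound 1, `COc1ccc(CNc2nc(N3CCN(C4CCCC4)CC3)c3ncn(CCCN4CCCC4)c3n2)cc1`, gives 240 nM
- compound 2, `CCN1CCN(CCCn2cnc3c(N4CCN(CC)CC4)nc(NCc4ccc(OC)cc4)nc32)CC1`, gives 200 nM
- compound 3, `CCN1CCN(CCCn2cnc3c(N4CCN(C5CCCC5)CC4)nc(NCc4ccc(N(CC)CC)cc4)nc32)CC1`, gives 150 nM

These three numbers come from an assay on HEK293 cells for antagonist activity at Toll-like receptor 9 (Homo sapiens), read by spectrophotometry; a lower number here means a stronger inhibitor, a higher number a weaker inhibitor. Among the compounds with values here, compound 3 has the lowest of the three values, but its nearest neighbour, compound 2, sits only a small distance away and compound 1 a little further, and both gaps are within the scatter; no compound can be called the strongest on this evidence.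

Compound 4, `CCN1CCN(CCCn2cnc3c(N4CCN(C5CCCC5)CC4)nc(NCc4ccc(OC)cc4)nc32)CC1`, has not yet been measured. It differs from compound 3 in one place: methoxy in place of diethylamino on an aromatic carbon. The methoxy-bearing benzyl group is already present in compound 1 and compound 2, whose values in this assay lie close to that of compound 3. Within the data shown here, with no measured step for this exact exchange, the expected step from compound 3 to compound 4 is a 1.3-fold higher number from compound 3 to compound 4 (0.10 log units; within the scatter), that is a slight rise in the number but not beyond the scatter. Compound 4 is therefore estimated at 190 nM, with a range from 90 nM to 400 nM.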

Compound 4, half-maximal inhibitory concentration: 120 nM
For compound 4 the middle estimate is 1.6-fold (0.20 log units) above the measured one; low and high end bracket the measured number.
By their numbers in this assay, from the lowest: compounds 4, 3, 2 and 1 (each within the scatter of the next).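

In this assay the exchange of 4-(diethylamino)benzyl for 4-methoxybenzyl gives a 1.3-fold lower number from compound 3 to compound 4 (0.10 log units; within the scatter) within the scatter, so at this place, para to a large group, a group of 5 heavy atoms and one of 2 cannot be told apart. Within the data shown here, the two other single changes, read for the first time, also stay within the scatter: cyclopentyl in place of ethyl on the ring amine nitrogen gives a 1.7-fold lower number from compound 2 to compound 4 (0.22 log units; within the scatter) and 4-ethylpiperazin-1-yl in place of pyrrolidin-1-yl on the saturated chain gives a 2.0-fold lower number from compound 1 to compound 4 (0.30 log units; within the scatter) at this end of the chain. No measured property of these compounds bears on these results.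

The compounds shown leave open whether any group at the aromatic carbon moves the number beyond the scatter, such as a primary amine, a carboxylic acid or a chlorine atom. They also leave open what a longer chain in place of the ethyl on the ring amine nitrogen would do.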